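Adding a Methyl to the Ring Amide Nitrogen

The compounds below may be only part of what the source reports. "The series", "measured", "known", "first", "only" and "open" are said of these compounds alone.

Two compounds have been measured so far:
compound 1, `CCc1nn(C)c2c1C(c1cccc(F)c1)=NCC(=O)N2C`: 32 mg/kg
compound 2, `CCc1nn(C)c2c1C(c1ccc(F)cc1)=NCC(=O)N2`: > 500 mg/kg

Both were tested in a functional assay on the whole organism with Rattus norvegicus as the target; a higher number here means that more compound is needed for the effect, a lower number that less compound is needed. Compound 1 gives 32 mg/kg. For compound 2 the reported value of > 500 mg/kg is a limit of the assay and not a number. Compound 2 thus stands at the limit of > 500 mg/kg in this assay, at which 1 of the 2 values shown sits, so no true dose is known for it. Compound 1 and compound 2 differ in two places at once, so their two values show only that one reaches the effect at a measured dose while the other does not within the tested range.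

Compound 3, `CCc1nn(C)c2c1C(c1ccc(F)cc1)=NCC(=O)N2C`, has not been measured. It differs from compound 2 by methyl in place of hydrogen on an amide-type nitrogen in a ring. For the measured compounds named here, compound 1 also carries a methyl on that nitrogen and gives 32 mg/kg, which is the only guide here, since no measured step isolates this single change. Compound 3 is therefore expected to need less compound than compound 2 in this assay, an expected step of an at least 8.3-fold lower number from compound 2 to compound 3 (0.92 log units; beyond the scatter) that goes beyond the scatter. The estimate for compound 3 is 60 mg/kg, with an expected range from 15 mg/kg to 300 mg/kg.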

Compound 3, minimum effective dose: > 500 mg/kg
Compound 3 gave a limit, no number; the forecaster's own chance of this, stated with the estimate: 25%; at least 8.3-fold (0.92 log units) between middle value and limit.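

With the methyl on the amide-type nitrogen present on both sides, a single change remains between the two methylated compounds: 4-fluorophenyl in place of 3-fluorophenyl on a carbon with a double bond to nitrogen, and in this assay this change gives an at least 15-fold higher number from compound 1 to compound 3 (1.19 log units; beyond the scatter), so the dose needed at this position depends strongly on which fluorophenyl group sits there. For compound 3, the result of > 500 mg/kg is a limit of the assay and not a number, which shows that the methyl does not by itself bring a measurable effect when 4-fluorophenyl is present. The step from hydrogen to methyl on the ring nitrogen cannot be read, since both compounds that carry 4-fluorophenyl end in the same way: the limit of > 500 mg/kg in this assay, at which 2 of the 3 values shown sit.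

Whether the methyl has any effect therefore stays open, both with 4-fluorophenyl and with 3-fluorophenyl, where the compounds shown include no partner with the amide hydrogen. Also open, going by these compounds, is how an unsubstituted phenyl or a 2-fluorophenyl group would behave at the same carbon, and what an ethyl group would do on the ring nitrogen.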